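The source may hold more compounds than are shown below. What is called first, only, known or untested is meant among the compounds shown, and "the series" means these compounds.

Compound 1 `O=C(Nc1ccc2nc(NC(=O)C3CCCCC3)sc2c1)c1ccc(Cl)cc1Cl`: in a functional assay on WI-38 VA13 cells (Homo sapiens) for cytotoxicity (on this read-out higher numbers stand for an effect only at larger amounts of compound and lower numbers for an effect already at smaller amounts), compound 1 gives > 4 ug/mL, which is a limit of the assay rather than a number.
Compound 2 `CCC(C)(C)C(=O)Nc1ccc2nc(NC(=O)C3CCCCC3)sc2c1`: in this assay compound 2 gives 1 ug/mL.

Compound 2 thus holds the only number shown in this assay; the other value is the limit (the limit of > 4 ug/mL in this assay, at which 1 of the 2 values shown sits). Compound 3 `Cc1coc(C)c1C(=O)Nc1ccc2nc(NC(=O)C3CCCCC3)sc2c1` differs from compound 2 in one place: 2,4-dimethylfuran-3-yl in place of 1,1-dimethylpropyl on a carbonyl carbon. Going by the values given here, the only measured step that bears on this is an at least 4.0-fold lower number from compound 1 to compound 2 (0.60 log units; beyond the scatter), where an aromatic ring on that carbonyl carbon was replaced by a branched alkyl group. Compound 3 moves in the opposite direction, putting a five-membered aromatic ring back onto the same carbonyl carbon, so a step back towards a higher number is expected, though its size from a single step is uncertain. For compound 3 the estimate is 3 ug/mL with a range from 1 ug/mL to 10 ug/mL. The expected step is a 3.0-fold higher number from compound 2 to compound 3 (0.48 log units; beyond the scatter).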

Compound 3, half-maximal effective concentration: 2.7 ug/mL
Compound 3: the middle estimate sits 1.1-fold (0.05 log units) above what was measured, and the stated range covers the measured number.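

In this assay, the earlier step rested on a limit, whereas this one gives a measured size for a change on the carbonyl carbon: 2,4-dimethylfuran-3-yl in place of 1,1-dimethylpropyl produces a 2.7-fold higher number from compound 2 to compound 3 (0.43 log units; beyond the scatter). Among the three compounds, the 1,1-dimethylpropyl group of compound 2 now stands with the lowest number, and both aromatic rings, six-membered in compound 1 and five-membered in compound 3, go with higher numbers. The two aromatic rings cannot be put in order, as the step reads an at least 1.4-fold lower number from compound 1 to compound 3 (0.17 log units; that floor lies within the scatter) and the value of compound 1 is a limit and not a number: the limit of > 4 ug/mL in this assay, at which 1 of the 3 values shown sits.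

Going by these compounds, it remains open whether the higher number follows the furan ring itself or its two methyl groups. Also open, on these data alone, is how a longer straight chain, a piperidine ring or a carboxylic acid on this carbonyl carbon would read.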